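Dichloro to difluoro on the aryl ketone of a pyrazolyl chalcone

The compounds below may be only part of what the source reports. "The series", "measured", "known", "first", "only" and "open" are said of these compounds alone.

Measured so far in a functional assay on A498 cells (Homo sapiens) for cytotoxicity, read by sulforhodamine B assay, with a stated time of 48 h, tested at 0.01 uM; a lower number here means a stronger effect, a higher number a weaker effect of the compound at the concentration tested:
- compound 1, `COc1cc(-c2cc(/C=C/C(=O)c3ccc(N)cc3)[nH]n2)cc(OC)c1OC`, 91%
- compound 2, `COc1cc(-c2cc(/C=C/C(=O)c3ccc(Cl)c(Cl)c3)[nH]n2)cc(OC)c1OC`, 84%
- compound 3, `COc1ccc(C(=O)/C=C/c2cc(-c3cc(OC)c(OC)c(OC)c3)n[nH]2)cc1`, 98%

Compound 3 stands highest of the three numbers in this assay. Its nearest neighbour is compound 1, with a number 7 percentage points higher from compound 1 to compound 3 (within the scatter), a step within the scatter, so the two cannot be ranked against each other. Its furthest is compound 2, with a number 14 percentage points higher from compound 2 to compound 3 (beyond the scatter), a modest step beyond the scatter.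

Compound 4 is `COc1cc(-c2cc(/C=C/C(=O)c3ccc(F)c(F)c3)[nH]n2)cc(OC)c1OC`. It differs from compound 3 in one place: 3,4-difluorophenyl in place of 4-methoxyphenyl on a carbonyl carbon.

Among the compounds with values here, the step that bears on this change is the one from compound 2 to compound 3, a number 14 percentage points higher from compound 2 to compound 3 (beyond the scatter), where a 4-methoxyphenyl replaced a 3,4-dichlorophenyl on the same carbonyl carbon. Compound 4 carries a 3,4-difluorophenyl at that position, a change in the same sense as going back from compound 3 toward compound 2. A step of similar size and downward direction is therefore expected for compound 4, estimated as a number 11 percentage points lower from compound 3 to compound 4 (beyond the scatter), though the fluorine-for-chlorine difference leaves room for it to be smaller. Compound 4 is expected to give about 87% in this assay, within a range of 75% to 99%.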

Compound 4, a percentage reported as activity, at one concentration (the size of the read-out at that concentration, not a potency): 100%
Estimate against measurement, compound 4: 13 percentage points below; measured number outside the range, above it.
By their numbers in this assay, from the lowest: compounds 2, 1, 3 and 4 (each within the scatter of the next, the first and the last beyond it).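

In this assay, the 3,4-difluorophenyl on the carbonyl carbon does not read like the 3,4-dichlorophenyl: the exchange of halogens gives a number 16 percentage points higher from compound 2 to compound 4 (beyond the scatter), so the lower number of compound 2 does not carry over to the other dihalogenated ring. Against the 4-methoxyphenyl the change gives a number 2 percentage points higher from compound 3 to compound 4 (within the scatter), and against the 4-aminophenyl it gives a number 9 percentage points higher from compound 1 to compound 4 (within the scatter), so these three aryl ketones cannot be ranked against one another and, of the three, only compound 4 and compound 3 stand apart from compound 2. Nothing available explains why the chlorine and fluorine compounds part here.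

The compounds shown leave open whether the number in this assay answers to chlorine specifically or to some wider feature of that ring. An unsubstituted phenyl, or a ring carrying a nitrile or a carboxylic acid, would test this at the same carbonyl carbon.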